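From a Pentyl Chain to a Hydroxypropyl Chain

A few compounds are considered here, and "the series" means these few. Any claim that something is new, unique, unknown or untested is made for them only; others in the source may bear on it.

Among the measured compounds shown here, compound 2 `CCCCCc1cn(C(c2ccccc2)c2cc3cc(Br)ccc3nc2OC)nn1` stands lowest of the two compounds measured so far in an ADME assay on HeLa cells (Homo sapiens) for cytotoxicity, read by sulforhodamine B assay, with a stated time of 48 h, tested at 10 uM (on this read-out higher numbers stand for more inhibition at the one concentration tested (going by the name of the read-out) and lower numbers for less inhibition), giving -9.81%. Compound 1 `COc1nc2ccc(Br)cc2cc1C(c1ccccc1)n1cc(-c2ccc(Br)cc2)nn1` gives 6.92%, and the step of a number 16.7 percentage points lower from compound 1 to compound 2 (beyond the scatter) separates them. Compound 3 `COc1nc2ccc(Br)cc2cc1C(c1ccccc1)n1cc(CCCO)nn1` differs from compound 2 by the change (hydroxy in place of ethyl on a saturated chain carbon, three bonds along the chain from an aromatic carbon). For the measured compounds named here, the one measured step exchanges a ring for a chain, and no measured step alters the end of a chain, so it offers no direct guide. In this assay a step within the scatter is therefore expected, a number 6.8 percentage points higher from compound 2 to compound 3 (within the scatter). Compound 3 is estimated at -3%, between -18% and 12%.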

Compound 3, a percentage reported as inhibition, at one concentration (the size of the read-out at that concentration, not a potency): 11.3%
Estimate against measurement, compound 3: 14.3 percentage points below, and the stated range covers the measured number.
By their numbers in this assay, from the lowest: compound 2; then compounds 1 and 3 (each within the scatter of the next).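

On this position the end of the chain counts, not only the exchange of ring for chain: in this assay putting hydroxy in place of ethyl gives a number 21.1 percentage points higher from compound 2 to compound 3 (beyond the scatter) on this read-out. With 3-hydroxypropyl in place of 4-bromophenyl the result is a number 4.4 percentage points higher from compound 1 to compound 3 (within the scatter) so this chain and the ring cannot be told apart here. Nothing at hand explains the shift.

From the compounds shown here alone, it remains open whether the hydroxy depends on its distance along the chain, as a 2-hydroxyethyl or a longer hydroxyalkyl chain would show. Whether an amine or a carboxylic acid at the chain end would act alike is also unknown.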